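Naphthyl to Dimethoxyphenyl: Expected Effect on Cell Viability

A few compounds are considered here, and "the series" means these few. Any claim that something is new, unique, unknown or untested is made for them only; others in the source may bear on it.

Measured in an ADME assay on Vero cells (Chlorocebus sabaeus) for cytotoxicity, read by MTT assay, tested at 100 uM; on this read-out lower numbers stand for a stronger effect and higher numbers for a weaker effect at the one concentration tested:
- compound 1 `CSc1ccc(C(=O)/C(=C/c2cc3ccccc3s2)c2ccc(Cl)c(Cl)c2)cc1` gives 87.1%
- compound 2 `CSc1ccc(C(=O)/C(=C/c2cccnc2)c2ccc(Cl)c(Cl)c2)cc1` gives 88.6%
- compound 3 `CCOC(=O)C(C(=O)c1ccc(OC)cc1)C(NC(C)=O)c1cccc2ccccc12` gives 95.5%

Compound 3 carries the highest number of the three, but its gaps to compound 2 and to compound 1 are both within the scatter, so the three compounds cannot be separated on this read-out. Compound 4 `CCOC(=O)C(C(=O)c1ccc(OC)cc1)C(NC(C)=O)c1ccc(OC)c(OC)c1` has not yet been measured. It differs from compound 3 in one place: 3,4-dimethoxyphenyl in place of naphthalen-1-yl on a saturated chain carbon bound to an amide-type nitrogen and a saturated chain carbon. The new group sits on a saturated chain carbon bound to an amide-type nitrogen and a saturated chain carbon.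

Among the compounds with values here, only one measured step exists, a number 1.5 percentage points higher from compound 1 to compound 2 (within the scatter), and it concerns a different core and a different kind of exchange, so it does not bear on this change. Nothing in the measured compounds speaks for a shift either way, and the step from compound 3 to compound 4 is therefore expected to stay within the scatter in this assay, at about a number 3.5 percentage points lower from compound 3 to compound 4 (within the scatter). Compound 4 is estimated to give roughly 92%, with a plausible range from 80% to 100%.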

Compound 4, a percentage reported as activity, at one concentration (the size of the read-out at that concentration, not a potency): 88.5%
Beside the measured number, compound 4's estimate is 3.5 percentage points above it, and the stated range covers the measured number.
By their numbers in this assay, from the lowest: compounds 1, 4, 2 and 3 (each within the scatter of the next).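

In this assay the exchange of naphthalen-1-yl for 3,4-dimethoxyphenyl, on a saturated chain carbon bound to an amide-type nitrogen and a saturated chain carbon, comes out as a number 7 percentage points lower from compound 3 to compound 4 (within the scatter) and is the only step shown for this place. The earlier compounds shown here offered no reading here, and this one shows that a group with 2 six-membered aromatic rings of carbon only and 0 hydrogen-bond acceptors can give way to one with a single such ring and 2 hydrogen-bond acceptors, at an equal count of 10 heavy atoms, without a difference that can be told from the scatter. Nothing measured here explains the size of this step or links it to any property of either group.

What the compounds shown leave open is whether a group without an aromatic ring at this place, such as cyclohexyl or a longer chain, or a phenyl ring carrying an amine or a carboxylic acid, would also stay inside the scatter. Going by these compounds, each compound also has a reading at one concentration only, so how the two groups compare at other concentrations stays open as well.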